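The source may hold more compounds than are shown below. What is called first, only, known or untested is meant among the compounds shown, and "the series" means these compounds.

Working notes on the series. In a functional assay on HeLa cells for antagonist activity at 5-hydroxytryptamine receptor 6 (Homo sapiens), read by cAMP accumulation and immunoassay (a higher number here means a weaker inhibitor, a lower number a stronger inhibitor), compound 1 `O=S(=O)(c1ccccc1F)c1cn(C2CCNC2)c2ncccc12` gives 50 nM. Compound 2 `CN1CCC(n2cc(S(=O)(=O)c3ccccc3F)c3cccnc32)C1` carries the change methyl in place of hydrogen on an amine nitrogen in a ring and in this assay compound 2 gives 186 nM; the step is a 3.7-fold higher number from compound 1 to compound 2 (0.57 log units; beyond the scatter). Compound 3 `O=S(=O)(c1ccc(Cl)cc1)c1cn(C2CCCNC2)c2ncccc12` rests on another core; the difference between the cores of compound 1 and compound 3 is not broken down here. In this assay compound 3 gives 682 nM, the highest number of the three measured compounds. Compound 4 `CN1CCCC(n2cc(S(=O)(=O)c3ccc(Cl)cc3)c3cccnc32)C1` is not yet measured. It differs from compound 3 by methyl in place of hydrogen on an amine nitrogen in a ring. This is the same kind of change as from compound 1 to compound 2, though the place differs: in compound 2 the amine nitrogen sits in a five-membered non-aromatic ring with 1 nitrogen, in compound 4 in a six-membered non-aromatic ring with 1 nitrogen. Within the data shown here, the step expected here, a 3.4-fold higher number from compound 3 to compound 4 (0.53 log units; beyond the scatter), is set near the measured size because a 3.7-fold higher number from compound 1 to compound 2 (0.57 log units; beyond the scatter) is the only precedent for this kind of change, on one core only. Compound 4 is expected to give 2300 nM, within 900 nM to 6000 nM.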

Compound 4, half-maximal inhibitory concentration: 28 nM
Compound 4: middle estimate off by 82-fold (1.91 log units), on the high side; the whole stated range lies above it.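

In this assay, methyl in place of hydrogen on the amine nitrogen gives a 24-fold lower number from compound 3 to compound 4 (1.39 log units; beyond the scatter), so the earlier step carries over to this core in neither size nor direction: the same change on two cores in this assay, a 3.7-fold higher number (0.57 log units; beyond the scatter) from compound 1 to compound 2 and a 24-fold lower number (1.39 log units; beyond the scatter) from compound 3 to compound 4, 91-fold (1.96 log units) apart, beyond the scatter of two such steps. Among these compounds, the result of this change therefore cannot be transferred from one core to another, and a step measured on one core gives no usable estimate for the other, though this rests on only two matched pairs. It does not show which difference between the cores is responsible: the pairs do not separate the ring that holds the amine nitrogen, five-membered in compound 2 and six-membered in compound 4, from the other differences between the core of compound 1 and the core of compound 3.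

Open, going by these compounds, is how an ethyl group or a longer chain on that amine nitrogen would read on either core. Also open, on these data alone, is whether the methyl step would reverse on two cores that differ in ring size alone.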